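The compounds below may be only part of what the source reports. "The series", "measured", "known", "first", "only" and "open" are said of these compounds alone.

Two analogues sharing the same core have been measured in a functional assay on T47D cells (Homo sapiens) for antiproliferative activity, read by MTT assay, with a stated time of 48 h; on this read-out higher numbers stand for weaker inhibition and lower numbers for stronger inhibition. Compound 1 `COc1ccc(NC(=O)Nc2nnc(Sc3ncnc4scc(-c5ccncc5)c34)s2)cc1` bears a methoxy on an aromatic carbon, while compound 2 `Cc1ccc(NC(=O)Nc2nnc(Sc3ncnc4scc(-c5ccncc5)c34)s2)cc1` bears a methyl in its place. In this assay compound 1 reaches only the assay limit, > 100000 nM. In this assay compound 2 gives 17800 nM, the only number shown, so it stands as the sole fixed point. Among the measured compounds shown here, the step of an at least 5.6-fold lower number from compound 1 to compound 2 (0.74 log units; beyond the scatter) is the single measured step; its size is known only as a lower bound because compound 1 sits at the limit of > 100000 nM in this assay, at which 1 of the 2 values shown sits.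

Compound 3 `COc1cccc(NC(=O)Nc2nnc(Sc3ncnc4scc(-c5ccncc5)c34)s2)c1` has not yet been measured. It differs from compound 2 by 3-methoxyphenyl in place of 4-methylphenyl on an amide-type nitrogen. For the measured compounds named here, this brings a methoxy back in while taking away the methyl that compound 2 carries, so the one measured step, which ran in favour of methyl, bears directly on it and points toward a higher number for compound 3, with a genuine chance that it too ends at the limit. Compound 3 is expected to read about 40000 nM in this assay, between 15000 nM and 110000 nM. The expected step of a 2.2-fold higher number from compound 2 to compound 3 (0.35 log units; beyond the scatter) is estimated to be a weakening.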

Compound 3, half-maximal inhibitory concentration: 56900 nM
The estimate for compound 3 lay 1.4-fold (0.15 log units) below the measured number; the range from low to high includes it.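

In this assay, compound 3 gives a fixed number for a methoxy-bearing phenyl on this amide-type nitrogen, where compound 1 had offered only a limit, so such a group can now be placed on the scale. The change to 3-methoxyphenyl gives a 3.2-fold higher number from compound 2 to compound 3 (0.50 log units; beyond the scatter), which puts both methoxy compounds on the weaker side of 4-methylphenyl and leaves compound 2 with the lowest number of the three. Moving from 4-methoxyphenyl to 3-methoxyphenyl gives an at least 1.7-fold lower number from compound 1 to compound 3 (0.24 log units; that floor lies within the scatter), and the true size of that step stays unknown because compound 1 is a limit and not a number: the limit of > 100000 nM in this assay, at which 1 of the 3 values shown sits.

The compounds shown do not separate the effect of the group from the effect of where it sits, since methyl appears only in 4-methylphenyl and no 3-methylphenyl stands beside 3-methoxyphenyl. They also leave open how a plain phenyl, a 4-chlorophenyl or a 4-aminophenyl on this nitrogen would read, and so whether 4-methylphenyl improves on the bare ring or only avoids the loss seen with methoxy.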